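Extending the Amine Chain from Compound 2 to Compound 3

The source may hold more compounds than are shown below. What is called first, only, known or untested is meant among the compounds shown, and "the series" means these compounds.

In a functional assay on PANC-1 cells (Homo sapiens) for cytotoxicity, read by MTT assay, with a stated time of 48 h (on this read-out lower numbers stand for stronger inhibition and higher numbers for weaker inhibition), compound 1 (`CC(C)=CCC/C(C)=C/CC/C(C)=C/CSc1ccccc1C(=O)NCCN`) gives > 50000 nM and this is a limit of the assay, not a number. Going by the values given here, compound 2 (`CC(C)=CCC/C(C)=C/CC/C(C)=C/CSc1ccccc1C(=O)NCCCN`) stands at 11800 nM as the only number so far. Compound 3 (`CC(C)=CCC/C(C)=C/CC/C(C)=C/CSc1ccccc1C(=O)NCCCCN`) follows with aminomethyl in place of amino on a saturated chain carbon, three bonds along the chain from an amide-type nitrogen (3-aminopropyl to 4-aminobutyl). Among the compounds with values here, the one measured step of this kind is an at least 4.2-fold lower number from compound 1 to compound 2 (0.62 log units; beyond the scatter) and it lies two bonds along the chain from the amide-type nitrogen. On this single precedent a further modest drop is expected, estimated as a 2.4-fold lower number from compound 2 to compound 3 (0.37 log units; beyond the scatter) in this assay (a lower number). Compound 3 is expected at 5000 nM (range 1800 nM to 14000 nM).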

Compound 3, half-maximal inhibitory concentration: 10500 nM
Compound 3: the middle estimate sits 2.1-fold (0.32 log units) below what was measured, within the range that was stated.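

In this assay, going from 3-aminopropyl to 4-aminobutyl gives a 1.1-fold lower number from compound 2 to compound 3 (0.05 log units; within the scatter), so at three bonds along the chain from the amide-type nitrogen the added aminomethyl does not repeat the earlier step. The longer chain still keeps its distance from the shortest one, with an at least 4.7-fold lower number from compound 1 to compound 3 (0.67 log units; beyond the scatter). Compound 1 stands at a limit of the assay, so this step is only a bound: the limit of > 50000 nM in this assay, at which 1 of the 3 values shown sits.

As far as these compounds go, whether a still longer chain would depart from this level stays open, as does the effect of a dimethylamine or a carboxylic acid in place of the amino group.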